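Compound 4: a new group on the carbonyl carbon

This account rests on a few compounds, and the source may have more. Where it says the series, first, only, none or still open, it means among the compounds named here.

Of the compounds shown here, three sharing one core have been tested in a functional assay on HepG2 cells (Homo sapiens) for inhibition, read by MTT assay, with a stated time of 48 h; on this read-out higher numbers stand for weaker inhibition and lower numbers for stronger inhibition. Compound 1 `COc1cc(-c2nnc(S)n2-c2ccc(N(C)C)cc2)cc(OC)c1OC` gives only a limit (> 60000 nM). Compound 2 `CCSc1nnc(-c2cc(OC)c(OC)c(OC)c2)n1-c1ccc(N(C)C)cc1` also gives only a limit (> 60000 nM). Compound 3 `COc1ccc(C(=O)CSc2nnc(-c3cc(OC)c(OC)c(OC)c3)n2-c2ccc(N(C)C)cc2)cc1O` likewise gives only a limit (> 100000 nM). Compound 3 therefore stands without a number of its own.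

Compound 4 `COc1cc(-c2nnc(SCC(=O)Nc3ccc(Cl)cc3)n2-c2ccc(N(C)C)cc2)cc(OC)c1OC` changes one place in compound 3: on a carbonyl carbon, (4-chlorophenyl)amino stands in place of 3-hydroxy-4-methoxyphenyl ((4-chlorophenyl)amino in place of 3-hydroxy-4-methoxyphenyl on a carbonyl carbon).

The closest evidence comes from the changes made on the sulfur. These are (a step that the two limits leave unreadable from compound 1 to compound 2), (a step that the two limits leave unreadable from compound 1 to compound 3) and (a step that the two limits leave unreadable from compound 2 to compound 3). None of them has a size that can be carried over to the new change, and none shows a direction. No clear step in either direction is therefore expected (an at least 1.6-fold lower number from compound 3 to compound 4 (0.22 log units; that floor lies within the scatter)), and another limit is quite possible. For compound 4 the estimated half-maximal inhibitory concentration in this assay is 60000 nM, with an expected range from 15000 nM to 150000 nM.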

Compound 4, half-maximal inhibitory concentration: > 60000 nM
Compound 4: no number, only a limit; the forecaster's own chance of this, stated with the estimate: 60%; the middle value lies on the limit itself.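

Compound 4 gives only a limit, as do compound 1, compound 2 and compound 3, so none of the steps to compound 4 can be read. The compounds shown leave open how strongly each inhibits in this assay, and whether any change on the sulfur or the carbonyl carbon alters that.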